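The source may report more compounds than this note shows. Statements on the series, on what has been measured and on what is new or still open speak of the compounds shown alone.

Measured in a functional assay on Z-138 cells (Homo sapiens) for antiproliferative activity, with a stated time of 72 h; on this read-out higher numbers stand for weaker inhibition and lower numbers for stronger inhibition:
- compound 1 `CCCCC#Cc1cc([C@@H]2O[C@H](CO)[C@@H](O)[C@H]2O)n2ncnc(N)c12`: 200 nM
- compound 2 `Nc1ncnn2c([C@@H]3O[C@H](CO)[C@@H](O)[C@H]3O)cc(C#CC3CC3)c12`: 20 nM
- compound 3 `Nc1ncnn2c([C@@H]3O[C@H](CO)[C@@H](O)[C@H]3O)cc(-c3ccc(F)cc3)c12`: > 100000 nM

The entry for compound 3 is a limit of the assay, not a number.

Compound 2 gives the lowest number of the three, and so the strongest inhibition, as shown by the step of a 10-fold lower number from compound 1 to compound 2 (1.00 log units; beyond the scatter). Compound 4 `Nc1ncnn2c([C@@H]3O[C@H](CO)[C@@H](O)[C@H]3O)cc(-c3ccc(F)cc3F)c12` differs from it as follows: 2,4-difluorophenyl in place of 2-cyclopropylethynyl on an aromatic carbon. In words, this is 2,4-difluorophenyl in place of 2-cyclopropylethynyl on an aromatic carbon.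

Among the measured compounds shown here, the closest precedent is the large step of an at least 5000-fold higher number from compound 2 to compound 3 (3.69 log units; beyond the scatter), where 4-fluorophenyl entered instead. The step of an at least 500-fold higher number from compound 1 to compound 3 (2.69 log units; beyond the scatter) is also large. A similarly large rise, meaning much weaker inhibition, is therefore expected, and the assay may report only a limit. The expected step is a 5000-fold higher number from compound 2 to compound 4 (3.70 log units; beyond the scatter). Compound 4 is estimated at 100000 nM, with an expected range of 20000 nM to 300000 nM.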

Compound 4, half-maximal inhibitory concentration: 59100 nM
The estimate for compound 4 lay 1.7-fold (0.23 log units) above the measured number, and the stated range covers the measured number.
By their numbers in this assay, from the lowest: compound 2; then compound 1; then compound 4. At a limit, above all of these: compound 3.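

In this assay, 2,4-difluorophenyl gives a 3000-fold higher number from compound 2 to compound 4 (3.47 log units; beyond the scatter) and a 300-fold higher number from compound 1 to compound 4 (2.47 log units; beyond the scatter), so a second phenyl-type group at this aromatic carbon, now with a true number, falls far behind both triple-bonded groups. Adding one fluoro to the phenyl ring gives an at least 1.6-fold lower number from compound 3 to compound 4 (0.22 log units; that floor lies within the scatter), so no real gain can be read from that change. Compound 3 stands at a limit: the limit of > 100000 nM in this assay, at which 1 of the 4 values shown sits.

Going by these compounds, it remains open how a small group on this carbon, such as methyl or an amine, would compare. Also open, on these data alone, is whether a triple-bonded group carrying a phenyl ring at its far end would keep the stronger inhibition.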